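The compounds below may be only part of what the source reports. "The series", "measured", "known", "first", "only" and "open" are said of these compounds alone.

Compound 1 `CCCn1c(=O)c2[nH]c(-c3ccccc3)nc2n(CCSCC)c1=O` holds the lowest of the two numbers in an assay on CHO cells for displacement of a labelled ligand from adenosine receptor A1 (Homo sapiens), read by scintillation counting (a lower number here means a stronger inhibitor, a higher number a weaker inhibitor), giving 93.3 nM. Compound 2 `CCSCCn1c(=O)n(CC)c(=O)c2[nH]c(-c3ccccc3)nc21` gives 148 nM in this assay, and the step of a 1.6-fold higher number from compound 1 to compound 2 (0.20 log units; within the scatter) stays within the scatter. Compound 3 `CCCn1c(=O)c2[nH]c(-c3ccccc3)nc2n(CC[S+]([O-])CC)c1=O` differs from compound 1 by a group of 4 heavy atoms (2 carbon, 1 oxygen, 1 sulfur; no ring) in place of a group of 3 heavy atoms (2 carbon, 1 sulfur; no ring), on a saturated chain carbon, two bonds along the chain from an aromatic nitrogen. For the measured compounds named here, no measured step touches this group; the only recorded step, a 1.6-fold higher number from compound 1 to compound 2 (0.20 log units; within the scatter), concerns a different chain carbon and gives no direct guide. With nothing in the series pointing either way, no change beyond the scatter is expected, with a slight lean toward a higher number. Compound 3 is therefore estimated at 160 nM, ranging from 60 nM to 450 nM, a step of a 1.7-fold higher number from compound 1 to compound 3 (0.23 log units; within the scatter).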

Compound 3, inhibition constant: 195 nM
Compound 3: the middle estimate sits 1.2-fold (0.09 log units) below what was measured; the range from low to high includes it.
By their numbers in this assay, from the lowest: compounds 1, 2 and 3 (each within the scatter of the next, the first and the last beyond it).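

Putting the group of 4 heavy atoms, with its added oxygen on sulfur, in place of ethylsulfanyl gives a 2.1-fold higher number from compound 1 to compound 3 (0.32 log units; beyond the scatter) in this assay and so moves the number beyond the scatter, though only modestly. This place, on a saturated chain carbon, two bonds along the chain from an aromatic nitrogen, therefore responds to a change at the sulfur, but the oxidised sulfur group is still accepted without a large loss. Nothing available explains this shift.

Still open, as far as these compounds go, is whether ethylsulfonyl, an amine or a longer chain here would go further in the same direction. Also open, from the compounds shown here alone, is whether the same change behaves alike on the core of compound 2.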